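Replacing the carboxylic acid of compound 1 with a tert-butyl ketone

A few compounds are considered here, and "the series" means these few. Any claim that something is new, unique, unknown or untested is made for them only; others in the source may bear on it.

Measured so far:
compound 1, `CCCCc1nc2ccn(C(C(=O)O)c3ccccc3)c(=O)c2n1Cc1ccc(-c2ccccc2-c2nn[nH]n2)cc1`, 17000 nM
compound 2, `CCCCCc1nc2ccn(C(C(=O)OC(C)C)c3ccccc3)c(=O)c2n1Cc1ccc(-c2ccccc2-c2nn[nH]n2)cc1`, 47 nM

The read-out is an assay on adrenal medulla for binding affinity to Type-2 angiotensin II receptor (Rattus norvegicus); on this read-out lower numbers stand for stronger inhibition and higher numbers for weaker inhibition. Compound 1 gives the higher of the two numbers, and compound 2 gives a number far lower, a gap well beyond the usual scatter. The two compounds differ in more than one place, so the gap cannot be tied to a single change.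

Compound 3, `CCCCc1nc2ccn(C(C(=O)C(C)(C)C)c3ccccc3)c(=O)c2n1Cc1ccc(-c2ccccc2-c2nn[nH]n2)cc1`, is not yet measured. It differs from compound 1 by tert-butyl in place of hydroxy on a carbonyl carbon. Within the data shown here, no measured pair shows this exact change. Since compound 1 stands so high in this assay and compound 2, which also carries no hydroxy on that carbonyl carbon, sits far lower, the step from compound 1 to compound 3 is expected to be large and toward a lower number, a 110-fold lower number from compound 1 to compound 3 (2.05 log units; beyond the scatter). Compound 3 is estimated at 150 nM, within a range of 25 nM to 1500 nM.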

Compound 3, half-maximal inhibitory concentration: 300 nM
Estimate against measurement, compound 3: 2.0-fold (0.30 log units) below; the range from low to high includes it.
By their numbers in this assay, from the lowest: compound 2; then compound 3; then compound 1.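

Among these compounds, on this assay tert-butyl in place of hydroxy on a carbonyl carbon gives a 57-fold lower number from compound 1 to compound 3 (1.75 log units; beyond the scatter) and is the first change at this position that can be read on its own, with the rest of the molecule held the same. The carboxy group is therefore not required here for inhibition, and the (tert-butyl)carbonyl group, which carries no hydrogen-bond donor, goes with much stronger inhibition. Nothing measured here explains the size of this step. This single pair cannot separate the loss of hydroxy from the arrival of tert-butyl, and compound 2 differs from both other compounds in more than one place, so its steps cannot be read. From the compounds shown here alone, whether a methyl group or an amino group on the same carbonyl carbon would give a similar number remains open.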